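The source may hold more compounds than are shown below. What is called first, only, known or untested is meant among the compounds shown, and "the series" means these compounds.

Measured compounds in a functional assay for inhibition of sodium/hydrogen exchanger (Oryctolagus cuniculus); a lower number here means a stronger inhibitor, a higher number a weaker inhibitor:
compound 1 `CCCc1cc(C)c(C(=O)N=C(N)N)cc1S(C)(=O)=O`, 5.7 nM
compound 2 `Cc1cc(Sc2ccccc2Cl)c(S(C)(=O)=O)cc1C(=O)N=C(N)N`, 14 nM
compound 3 `COc1cc(C)c(C(=O)N=C(N)N)cc1S(C)(=O)=O`, 16 nM

Compound 3 gives the highest of the three numbers in this assay. Its nearest neighbour is compound 2, where the gap, a 1.1-fold higher number from compound 2 to compound 3 (0.06 log units; within the scatter), lies within the scatter, so the two are not ordered. Compound 1 stands further off: a 2.8-fold higher number from compound 1 to compound 3 (0.45 log units; beyond the scatter), and the parallel step a 2.5-fold higher number from compound 1 to compound 2 (0.39 log units; beyond the scatter), both modest and beyond the scatter.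

Compound 4 `Cc1cc(Oc2cccc(Cl)c2)c(S(C)(=O)=O)cc1C(=O)N=C(N)N` is not yet measured. It differs from compound 3 in one place: 3-chlorophenyl in place of methyl on an oxygen on an aromatic ring. Among the compounds with values here, the step that bears on it most directly is the one from compound 2 to compound 3, where an aryl group on sulfur in place of methoxy left the number unchanged within the scatter. Within the data shown here, compound 4 carries an aryl group on oxygen instead; no measured pair separates an oxygen-linked from a sulfur-linked aryl group, nor a 3-chlorophenyl from a 2-chlorophenyl, so that part is open. The expectation below rests on that step, a 1.1-fold higher number from compound 2 to compound 3 (0.06 log units; within the scatter). For compound 4 the expected step in this assay is one within the scatter, a 1.1-fold lower number from compound 3 to compound 4 (0.06 log units; within the scatter), in no firm direction. The number for compound 4 is therefore estimated at 14 nM, with a range of 6 nM to 35 nM.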

Compound 4, half-maximal inhibitory concentration: 21 nM
Compound 4: the middle estimate sits 1.5-fold (0.18 log units) below what was measured; low and high end bracket the measured number.
By their numbers in this assay, from the lowest: compound 1; then compounds 2, 3 and 4 (each within the scatter of the next).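

In this assay the methyl on the oxygen on the aromatic ring gives way to 3-chlorophenyl with a 1.3-fold higher number from compound 3 to compound 4 (0.12 log units; within the scatter) following, so a single carbon and an aromatic ring of seven heavy atoms cannot be told apart at this place. The oxygen-linked aryl group also stays level with the sulfur-linked one, with a 1.5-fold higher number from compound 2 to compound 4 (0.18 log units; within the scatter) as the reading, but that step changes the linking atom and the place of the chlorine together, so neither change can be read alone. Propyl remains the only group set apart from the others, with a 3.7-fold higher number from compound 1 to compound 4 (0.57 log units; beyond the scatter) showing a modest gap beyond the scatter, and nothing on hand speaks to what lies behind that gap.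

As far as these compounds go, without a pair that holds the aryl group fixed while the linking atom changes, or one that moves only the chlorine, the separate contributions of these two features remain open. Also open, from the compounds shown here alone, is how an amine such as piperidine, or a chain longer than propyl such as pentyl, would read on this aromatic carbon.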